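This account rests on a few compounds, and the source may have more. Where it says the series, first, only, none or still open, it means among the compounds named here.

Of the compounds shown here, three built on one shared core have so far been tested in a functional assay on H184B5F5/M10 cells (Homo sapiens) for antiproliferative activity, read by XTT assay, with a stated time of 72 h; on this read-out lower numbers stand for stronger inhibition and higher numbers for weaker inhibition. Compound 1 `COc1ccc(C(=O)/C=C/c2nc3ccccc3cc2-c2ccc(OC)cc2)cc1` reaches only a limit, > 10000 nM, in this assay. The value of compound 1 sits at the limit of > 10000 nM in this assay, at which 1 of the 3 values shown sits. Compound 2 `COc1ccc(-c2cc3ccccc3nc2/C=C/C(=O)c2ccc(N)cc2)cc1` gives 9290 nM in this assay, and compound 3 `COc1ccc(-c2cc3ccccc3nc2/C=C/C(=O)c2ccsc2)cc1` gives 6390 nM in this assay. Among the two numbers shown, compound 2 has the higher one, and its nearest neighbour is compound 3, separated by a 1.5-fold lower number from compound 2 to compound 3 (0.16 log units; within the scatter); that gap stays within the scatter. The step from compound 1 to compound 3, an at least 1.5-fold lower number from compound 1 to compound 3 (0.19 log units; that floor lies within the scatter), is likewise no more than the scatter allows.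

Compound 4 `COc1ccc(-c2cc3ccccc3nc2/C=C/C(=O)c2c[nH]c3ccccc23)cc1` has not yet been measured. It departs from compound 2 as follows: 1H-indol-3-yl in place of 4-aminophenyl on a carbonyl carbon. The two measured steps that bear on it are the ones that also exchange the group on the carbonyl carbon, a 1.5-fold lower number from compound 2 to compound 3 (0.16 log units; within the scatter) and an at least 1.5-fold lower number from compound 1 to compound 3 (0.19 log units; that floor lies within the scatter); neither moved the read-out beyond the scatter. A step of similar size is therefore expected for compound 4, at most a modest lowering, expressed as a 1.5-fold lower number from compound 2 to compound 4 (0.19 log units; within the scatter). On that basis compound 4 is estimated to give 6000 nM in this assay, with the expected range running from 2000 nM to 18000 nM.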

Compound 4, half-maximal inhibitory concentration: > 10000 nM
Compound 4: only a limit was reported; the forecaster's own chance of this, stated with the estimate: 25%; middle value at least 1.6-fold (0.22 log units) away from the limit.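

In this assay compound 4 gives only a limit, > 10000 nM, and compound 1 ends at that same limit: the limit of > 10000 nM in this assay, at which 2 of the 4 values shown sit. Exchanging 4-aminophenyl for 1H-indol-3-yl on the carbonyl carbon gives an at least 1.0-fold higher number from compound 2 to compound 4 (0.03 log units; that floor lies within the scatter), and exchanging thiophen-3-yl for it gives an at least 1.5-fold higher number from compound 3 to compound 4 (0.19 log units; that floor lies within the scatter), while the step linking the two limits cannot be read. This position has now carried a group with a five-membered and a six-membered aromatic ring as well as the single-ring groups, and no readable step has yet been shown to pass the scatter in either direction, although the two floors do not fix how large the true steps to compound 4 are.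

As far as these compounds go, it remains open whether any group on this carbonyl carbon can move the read-out beyond the scatter, for instance a 4-hydroxyphenyl, a pyridin-3-yl or a phenyl bearing a carboxylic acid. The 4-methoxyphenyl on the shared core stays the same in all four compounds, so what a plain phenyl or a 4-chlorophenyl would do there is also unknown.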